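A Benzyl Amide Expected to Stay Inactive

The compounds below may be only part of what the source reports. "The series", "measured", "known", "first", "only" and "open" are said of these compounds alone.

Compound 3 `C=CC1=C(C(=O)Nc2cccc(C)c2)C(c2ccc(F)cc2)OC1` is an amide built on the shared core. In a functional assay on A549 cells (Homo sapiens) for cytotoxicity, read by MTT assay, with a stated time of 24 h (on this read-out lower numbers stand for stronger inhibition and higher numbers for weaker inhibition), compound 3 gives only a limit, > 100000 nM. Compound 1 `C=CC1=C(C(=O)NCc2ccccc2)C(c2ccc(OC)cc2)OC1` likewise gives only a limit in this assay, > 100000 nM. Compound 2 `C=CC1=C(C(=O)NCc2ccc(Cl)cc2)C(c2ccc(F)cc2)OC1` also gives only a limit, > 100000 nM. Within the data shown here, all three values thus sit at the limit of > 100000 nM in this assay, at which 3 of the 3 values shown sit, and the single measured step, a step that the two limits leave unreadable from compound 2 to compound 3, cannot be read in size or direction: both of its ends are limits.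

Compound 4 `C=CC1=C(C(=O)NCc2ccccc2)C(c2ccc(F)cc2)OC1` has not yet been measured. It differs from compound 3 by benzyl in place of 3-methylphenyl on an amide-type nitrogen. No measured step speaks to this change, and the only step shown is unreadable. The values of compound 1 and compound 2 show that neither a benzyl nor a substituted benzyl on the amide nitrogen gave a number within the range of this assay.

Compound 4 is therefore expected to show no step beyond the scatter, a step that the limit leaves unreadable from compound 3 to compound 4, and most likely to return a limit again. The estimate for compound 4 is 150000 nM, within a range from 50000 nM to 500000 nM.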

Compound 4, half-maximal inhibitory concentration: > 100000 nM
Compound 4: no number, only a limit (the forecaster's own chance of this, stated with the estimate: 85%); the middle value is on the limit's open side.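

Compound 4 gives only a limit (> 100000 nM). Its steps from compound 1, compound 2 and compound 3 cannot be read, since both ends of each are limits: the limit of > 100000 nM in this assay, at which 4 of the 4 values shown sit. The compounds shown leave open what change to the shared core, if any, would give a measurable number in this assay rather than a limit.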